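The compounds below may be only part of what the source reports. "The series", "measured", "known", "first", "only" and "open" are said of these compounds alone.

In an ADME assay on liver (Mesocricetus auratus) for metabolic stability, using microsomes (on this read-out higher numbers stand for fast clearance and lower numbers for slow clearance), compound 1 (`O=C(Nc1[nH]nc(-c2ccccn2)c1C1CC1)c1ccccc1F`) gives > 100 mL.min-1.g-1 as a limit of the assay and not a number. Compound 2 (`COc1ccc(C(=O)Nc2[nH]nc(-c3ccccn3)c2C2CC2)cc1`) likewise gives > 100 mL.min-1.g-1 as a limit and not a number. Compound 3 (`O=C(Nc1cc(-c2ccccn2)n[nH]1)N1CCC(Oc2ccccc2)CC1`) gives 98.5 mL.min-1.g-1 as a true number rather than a limit. Compound 2 therefore stands at the limit of > 100 mL.min-1.g-1 in this assay, at which 2 of the 3 values shown sit, and has no number of its own.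

Compound 4 (`COc1ccccc1C(=O)Nc1[nH]nc(-c2ccccn2)c1C1CC1`) alters compound 2 in one place (2-methoxyphenyl in place of 4-methoxyphenyl on a carbonyl carbon) with 2-methoxyphenyl in place of 4-methoxyphenyl on a carbonyl carbon. For the measured compounds named here, the only measured step that bears on this change is a step that the two limits leave unreadable from compound 1 to compound 2 and it offers no size to build on. Compound 1 carries 2-fluorophenyl on that carbonyl carbon and stands at the limit > 100 mL.min-1.g-1 in this assay as well. On this evidence no step beyond the usual scatter is expected in this assay and neither direction is favoured. The expected change is a step that the limit leaves unreadable from compound 2 to compound 4 as an estimate. Compound 4 is estimated at 120 mL.min-1.g-1 with an expected range from 60 mL.min-1.g-1 to 240 mL.min-1.g-1 and may again be only a limit.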

Compound 4, intrinsic clearance in microsomes: > 100 mL.min-1.g-1
Compound 4: no number, only a limit; the forecaster's own chance of this, stated with the estimate: 65%; the middle value is on the limit's open side.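

Compound 4, like compound 1 and compound 2, gives only a limit of the assay and not a number in this assay, so no new step can be read among these three compounds. They share the same limit: the limit of > 100 mL.min-1.g-1 in this assay, at which 3 of the 4 values shown sit.

The compounds shown leave open how 2-methoxyphenyl, 4-methoxyphenyl and 2-fluorophenyl on that carbonyl carbon compare in clearance.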